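Trifluoromethyl to chloro on the pendant aryl ring

The compounds below may be only part of what the source reports. "The series", "measured", "known", "first", "only" and "open" are said of these compounds alone.

Measured so far in a functional assay on A-375 cells (Homo sapiens) for cytotoxicity, read by MTT assay; on this read-out higher numbers stand for weaker inhibition and lower numbers for stronger inhibition:
compound 1 `O=S(=O)(NCCNc1nccc(-c2c(-c3cccc(F)c3)nc3sccn23)n1)c1ccc(Cl)cc1` gives 18600 nM
compound 2 `O=S(=O)(NCCNc1nccc(-c2c(-c3cccc(F)c3)nc3sccn23)n1)c1ccc(C(F)(F)F)cc1` gives 7440 nM
compound 3 `O=C(NCCNc1nccc(-c2c(-c3cccc(F)c3)nc3sccn23)n1)c1ccc(C(F)(F)F)cc1` gives 8710 nM

Compound 2 and compound 1 share the sulfonamide link and differ by chloro in place of trifluoromethyl on an aromatic carbon; that change gives a 2.5-fold higher number from compound 2 to compound 1 (0.40 log units; beyond the scatter). Compound 3 differs from compound 2 in more than one place; the difference between the two cores is not broken down here, and their two values lie within the usual scatter of each other. A further step runs a 2.1-fold lower number from compound 1 to compound 3 (0.33 log units; beyond the scatter).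

Compound 4 `O=C(NCCNc1nccc(-c2c(-c3cccc(F)c3)nc3sccn23)n1)c1ccc(Cl)cc1` is not yet measured. It differs from compound 3 by chloro in place of trifluoromethyl on an aromatic carbon, the same change as made in the sulfonamide pair, at the same place. Among the compounds with values here, from compound 3 to compound 4 a step of a 2.3-fold higher number from compound 3 to compound 4 (0.36 log units; beyond the scatter) in this assay is expected, resting on the single earlier instance a 2.5-fold higher number from compound 2 to compound 1 (0.40 log units; beyond the scatter) and on compound 3 giving 8710 nM. Compound 4 is estimated at 20000 nM, between 9000 nM and 45000 nM.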

Compound 4, half-maximal inhibitory concentration: 2570 nM
Estimate against measurement, compound 4: 7.8-fold (0.89 log units) above, and the stated range ends above it.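

Chloro in place of trifluoromethyl does not carry over from one core to the other in this assay, and its direction reverses with the link: the same change on two cores in this assay, a 2.5-fold higher number (0.40 log units; beyond the scatter) from compound 2 to compound 1 and a 3.4-fold lower number (0.53 log units; beyond the scatter) from compound 3 to compound 4, 8.5-fold (0.93 log units) apart, beyond the scatter of two such steps

On the carbonyl core the change gives a 3.4-fold lower number from compound 3 to compound 4 (0.53 log units; beyond the scatter), while carbonyl in place of sulfonyl with the 4-chlorophenyl group held fixed gives a 7.2-fold lower number from compound 1 to compound 4 (0.86 log units; beyond the scatter). A step read on one core is therefore no guide to the other in this pair of cores, but two pairs do not show why the direction differs or how the change would run on any further core.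

Still open, on these data alone, is whether a nitrile or methoxy group on that aromatic carbon would behave alike on both links. A longer chain in the linker is also untested in the compounds shown.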